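A few compounds are considered here, and "the series" means these few. Any claim that something is new, unique, unknown or untested is made for them only; others in the source may bear on it.

Working notes on the series around compound 2 `Nc1nc2cc(Cl)c(Cl)cc2n1COC(CO)CO`. In a functional assay on KB cells (Homo sapiens) for inhibition (on this read-out lower numbers stand for stronger inhibition and higher numbers for weaker inhibition), compound 2 reaches only the limit of the assay, > 100000 nM, so no number stands for it. Compound 1 `OCC(CO)OCn1c(Cl)nc2c(Cl)c(Cl)ccc21` likewise returns only a limit in this assay, > 100000 nM. Compound 3 `CN(C)c1nc2cc(Cl)c(Cl)cc2n1COC(CO)CO` also returns only a limit, > 100000 nM. Among the compounds with values here, the one single-point step measured, a step that the two limits leave unreadable from compound 2 to compound 3, cannot be sized; all three measured compounds sit at the limit of > 100000 nM in this assay, at which 3 of the 3 values shown sit. Within the data shown here, compound 2 therefore has no place on a numeric scale: it is a limit among limits, and no measured compound is distinguishable from it.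

Compound 4 `OCC(CO)OCn1c(SCc2ccccc2)nc2cc(Cl)c(Cl)cc21` is the next compound to be measured. Relative to compound 2 the change is benzylsulfanyl in place of amino on an aromatic carbon: the amino group leaves and a benzylsulfanyl group enters, bringing one six-membered aromatic ring of carbon only. Among the measured compounds shown here, no measured step bears on this change; the only step recorded, a step that the two limits leave unreadable from compound 2 to compound 3, concerns dimethylamino in place of amino and is unreadable. No direction can be read for compound 4 in this assay from the measured compounds. Because compound 1, compound 2 and compound 3 all sit at the limit of > 100000 nM in this assay, at which 3 of the 3 values shown sit, compound 4 is expected to remain weak as well. The expected step that the limit leaves unreadable from compound 2 to compound 4 is therefore not resolvable against a limit. Compound 4 is estimated at 150000 nM, between 20000 nM and 1000000 nM.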

Compound 4, half-maximal inhibitory concentration: > 100000 nM
Compound 4 was reported as a limit (the forecaster's own chance of this, stated with the estimate: 75%); the middle value does not contradict the limit.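

In this assay compound 4 gives > 100000 nM, a limit and not a number, so the steps to it from compound 2 and from compound 3 cannot be read. The compounds shown leave open whether any change to the group on this aromatic carbon gives a measurable inhibition, since all of them stay at the limit: the limit of > 100000 nM in this assay, at which 4 of the 4 values shown sit.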